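The compounds below may be only part of what the source reports. "The series", "measured", "known", "first", "only" and "open" are said of these compounds alone.

Measured so far:
compound 1 `COc1cc(-c2nnc(SCc3cccc(Br)c3)o2)ccc1O` — 48100 nM
compound 2 `COc1cc(-c2nnc(SCc3cccc([N+](=O)[O-])c3)o2)ccc1O` — 16000 nM

In a functional assay on cells (T-cell, Mus musculus, strain BALB/c) for inhibition, read by MTT assay, with stated times of 24 h and 72 h (on this read-out higher numbers stand for weaker inhibition and lower numbers for stronger inhibition), compound 1 gives the highest of the two numbers; its nearest neighbour is compound 2, with a 3.0-fold lower number from compound 1 to compound 2 (0.48 log units; beyond the scatter). Compound 3 `COc1cc(-c2nnc(SCc3c(F)cccc3F)o2)ccc1O` is unmeasured and differs from compound 1 by 2,6-difluorophenyl in place of 3-bromophenyl on a saturated chain carbon bound to a sulfur. Among the compounds with values here, the only step on record, from compound 1 to compound 2, changes a different group on the same ring, so it gives no direct guide here; it shows only that a single change on this ring moved the number modestly. For compound 3 a step no larger than that is expected, with no sure direction, so a 1.2-fold lower number from compound 1 to compound 3 (0.08 log units; within the scatter) is expected to stay within the scatter. Compound 3 is estimated at 40000 nM, ranging from 12000 nM to 130000 nM.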

Compound 3, half-maximal inhibitory concentration: 10100 nM
Compound 3: middle estimate off by 4.0-fold (0.60 log units), on the high side; measured number outside the range, below it.
By their numbers in this assay, from the lowest: compounds 3 and 2 (each within the scatter of the next); then compound 1.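

In this assay, 2,6-difluorophenyl in place of 3-bromophenyl on a saturated chain carbon bound to a sulfur gives a 4.8-fold lower number from compound 1 to compound 3 (0.68 log units; beyond the scatter), so replacing the whole aryl group here moves the number beyond the scatter. Compound 3 and compound 2 lie within the scatter of each other, although they carry different groups. Nothing available accounts for the step. Open, going by these compounds, is whether the fluorines, their number or the loss of bromine drives the step; plain phenyl, 2-fluorophenyl or an aminophenyl group would help separate these.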